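Methyl Position on the Benzyl Group in a Urea Series

A few compounds are considered here, and "the series" means these few. Any claim that something is new, unique, unknown or untested is made for them only; others in the source may bear on it.

Measured so far, in an assay on HEK293 cells for displacement of a labelled ligand from Urotensin-2 receptor (Homo sapiens); a lower number here means a stronger inhibitor, a higher number a weaker inhibitor:
compound 1, `CCc1cc(NC(=O)NCCN2CCC(O)(Cc3ccccc3)CC2)c2sccc2n1`, gives 60 nM;
compound 2, `Cc1ccccc1CC1(O)CCN(CCNC(=O)Nc2ccnc3ccsc23)CC1`, gives 20 nM;
compound 3, `Cc1cccc(CC2(O)CCN(CCNC(=O)Nc3ccnc4ccsc34)CC2)c1`, gives 140 nM.

Compound 3 has the highest number of the three in this assay, with compound 1 nearest and compound 2 furthest below it. Compound 4, `Cc1ccc(CC2(O)CCN(CCNC(=O)Nc3ccnc4ccsc34)CC2)cc1`, differs from compound 3 only in this: 4-methylphenyl in place of 3-methylphenyl on a saturated chain carbon bound to a saturated ring carbon. Among the measured compounds shown here, the one step that bears on it is a 7.0-fold higher number from compound 2 to compound 3 (0.85 log units; beyond the scatter), which shows that where the methyl sits on this ring matters beyond the scatter. For the measured compounds named here, no measured pair tells which way a further move acts. Compound 3 is therefore taken as the anchor, and compound 4 is expected to give 150 nM (range 50 nM to 500 nM), a step of a 1.1-fold higher number from compound 3 to compound 4 (0.03 log units; within the scatter) that is expected to stay within the scatter.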

Compound 4, half-maximal inhibitory concentration: 190 nM
Estimate against measurement, compound 4: 1.3-fold (0.10 log units) below; the measured number falls inside the stated range.
By their numbers in this assay, from the lowest: compound 2; then compound 1; then compounds 3 and 4 (each within the scatter of the next).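

In this assay, the change from 3-methylphenyl to 4-methylphenyl gives a 1.4-fold higher number from compound 3 to compound 4 (0.13 log units; within the scatter), so these two placements of the methyl cannot be told apart. The change from 2-methylphenyl to 4-methylphenyl gives a 9.5-fold higher number from compound 2 to compound 4 (0.98 log units; beyond the scatter), so among these three compounds only the 2-methylphenyl group stands apart, and compound 3 and compound 4 form a single level. Nothing at hand gives a reason for this difference. The compounds shown leave open whether a 2-chlorophenyl or 2-methoxyphenyl group at this place would match compound 2, so it remains unknown whether the effect is specific to the methyl.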